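Swapping Trifluoromethyl for Chloro

The source may report more compounds than this note shows. Statements on the series, on what has been measured and on what is new or still open speak of the compounds shown alone.

In a functional assay on A-375 cells (Homo sapiens) for antiproliferative activity, read by MTT assay (a lower number here means a stronger inhibitor, a higher number a weaker inhibitor), compound 1 `Cc1nn2c(-c3nc4cc(C(F)(F)F)ccc4[nH]3)c(-c3ccccc3)nc2s1` gives 5200 nM and compound 2 `Cc1nn2c(-c3nc4cc(C(F)(F)F)ccc4[nH]3)c(-c3ccc(F)cc3)nc2s1` gives 7300 nM, so these two lie within the scatter of each other. Compound 3 `Cc1nn2c(-c3nc4cc(F)ccc4[nH]3)c(-c3ccccc3)nc2s1` has the highest number of the three, at 18100 nM, which leaves compound 2 second highest.

The next molecule, compound 4 `Cc1nn2c(-c3nc4cc(Cl)ccc4[nH]3)c(-c3ccc(F)cc3)nc2s1`, differs from compound 2 in one group: chloro in place of trifluoromethyl on an aromatic carbon. In words, this is chloro in place of trifluoromethyl on an aromatic carbon.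

Going by the values given here, two measured steps bear on it. The closer one is a 3.5-fold higher number from compound 1 to compound 3 (0.54 log units; beyond the scatter), with fluoro in place of trifluoromethyl on an aromatic carbon. The other, a 1.4-fold higher number from compound 1 to compound 2 (0.15 log units; within the scatter), is fluoro in place of hydrogen on an aromatic carbon, so compound 2 serves as a reasonable starting point much as compound 1 would. Chloro itself has not been measured in this series, so only a smaller upward move than the fluoro swap is expected. The expected change is a 1.5-fold higher number from compound 2 to compound 4 (0.18 log units; within the scatter). For compound 4 the estimate is 11000 nM, with an expected range of 5000 nM to 24000 nM.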

Compound 4, half-maximal inhibitory concentration: 4800 nM
Compound 4: middle estimate off by 2.3-fold (0.36 log units), on the high side, outside the stated range (below it).
By their numbers in this assay, from the lowest: compounds 4, 1 and 2 (each within the scatter of the next); then compound 3.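

In this assay the swap gives a 1.5-fold lower number from compound 2 to compound 4 (0.18 log units; within the scatter) and so shows that, at this place on the fused ring system, a single chloro can stand in for the four heavy atoms of trifluoromethyl with no change beyond the scatter. Going by these compounds alone, the only earlier swap of trifluoromethyl here, with fluoro, gave a 3.5-fold higher number from compound 1 to compound 3 (0.54 log units; beyond the scatter) on compounds that lack the fluoro carried by compound 2 and compound 4, so replacements of trifluoromethyl need not all read alike at this position. Nothing measured here explains why chloro and trifluoromethyl give such similar numbers.

Going by these compounds, whether chloro reads the same way with the hydrogen that compound 1 carries in place of that fluoro remains open. So does the outcome with a methoxy group or an amine at this same place.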